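Aminoisoxazole series: methyl on the five-membered ring

The source may report more compounds than this note shows. Statements on the series, on what has been measured and on what is new or still open speak of the compounds shown alone.

Compound 1 `Nc1oncc1-c1ccccc1`: 85 nM in an assay on SW48 cells for inhibition of Tryptophan 2,3-dioxygenase (Homo sapiens), read by fluorescence, with a stated time of 30 min; on this read-out lower numbers stand for an effect already at smaller amounts and higher numbers for an effect only at larger amounts of compound
Compound 2 `COc1cccc(-c2cnoc2N)c1`: 1500 nM
Compound 3 `Nc1oncc1-n1cccn1`: 230 nM

Three compounds share the aminoisoxazole core and differ in the ring attached to it. Compound 3 stands second highest of the three numbers in this assay: compound 1 gives 85 nM and sits lower, while compound 2 gives 1500 nM and sits well higher. Among the compounds with values here, the one step measured so far is an 18-fold higher number from compound 1 to compound 2 (1.25 log units; beyond the scatter), a large rise on adding a methoxy group to the six-membered ring.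

Compound 4 `Cc1ccn(-c2cnoc2N)n1` is the next point. Relative to compound 3 the change is methyl in place of hydrogen on an aromatic carbon. Within the data shown here, no measured step touches this ring; the methoxy step from compound 1 to compound 2 concerns a different group on a different ring and bears on the present change only loosely, so its size is not a direct guide. Among the measured compounds shown here, with a single small group entering and no direct precedent, the expectation is a modest step, if any, more likely upward than downward, and possibly within the scatter: a 1.5-fold higher number from compound 3 to compound 4 (0.18 log units; within the scatter). Compound 4 is therefore estimated at 350 nM in this assay, with a range from 120 nM to 1100 nM.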

Compound 4, half-maximal effective concentration: 810 nM
For compound 4 the middle estimate is 2.3-fold (0.36 log units) below the measured one; the measured number falls inside the stated range.
By their numbers in this assay, from the lowest: compound 1; then compound 3; then compounds 4 and 2 (each within the scatter of the next).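

In this assay a single methyl on an aromatic carbon of the five-membered aromatic ring with 2 nitrogen already shifts the number, with a 3.5-fold higher number from compound 3 to compound 4 (0.55 log units; beyond the scatter) as a modest step. This is the first measured change on this ring, so this position is shown to respond to a small group entering. The direction matches an 18-fold higher number from compound 1 to compound 2 (1.25 log units; beyond the scatter) on the six-membered ring, and in both of these pairs a group entering on the ring attached to the shared core goes with a higher number, with neither pair going against it. No measurement at hand accounts for the step.

On these data alone, it remains open whether the rise follows from methyl as such or from this particular place, and how a chlorine, an amine or a carboxylic acid on the same carbon would compare with methyl. Also open, as far as these compounds go, is whether the same methyl on the six-membered ring of compound 1 would shift the number in the same direction, which would show whether the trend holds across both ring types.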